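This account rests on a few compounds, and the source may have more. Where it says the series, first, only, none or still open, it means among the compounds named here.

In a functional assay on MGC-803 cells (Homo sapiens) for antiproliferative activity, read by MTT assay, with a stated time of 48 h (on this read-out lower numbers stand for stronger inhibition and higher numbers for weaker inhibition), the measured compounds so far are:
compound 1 `COc1cc(N(Cc2ccc(C)cc2)C(=O)CSc2nc3ccccc3s2)cc(OC)c1OC` gives 54200 nM
compound 2 `COc1ccc(CN(C(=O)CSc2nc3ccccc3s2)c2cc(OC)c(OC)c(OC)c2)cc1OC` gives 34100 nM

Compound 2 has a single neighbour on these numbers, compound 1, and the two values lie within the scatter of each other, so neither can be ranked over the other.

The next compound is compound 3 `COc1ccc(CN(C(=O)CSc2nc3ccccc3s2)c2cc(OC)c(OC)c(OC)c2)cc1Br`, which differs from compound 2 in one place: 3,4-dimethoxybenzyl becomes 3-bromo-4-methoxybenzyl, with bromo in place of methoxy on an aromatic carbon.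

For the measured compounds named here, no measured compound carries bromo, so the data give no direct size for this exchange. Going by the values given here, only one measured step concerns the same group, the replacement of 4-methylphenyl by 3,4-dimethoxyphenyl, and it is small: a 1.6-fold lower number from compound 1 to compound 2 (0.20 log units; within the scatter) in this assay. On that single precedent, no step beyond the scatter is expected in either direction, though the evidence is thin and the range is kept wide. The estimated step is a 1.1-fold lower number from compound 2 to compound 3 (0.06 log units; within the scatter) and it remains an expectation only. The value expected for compound 3 is 30000 nM with an estimated range from 10000 nM to 70000 nM around it.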

Compound 3, half-maximal inhibitory concentration: 852 nM
Beside the measured number, compound 3's estimate is 35-fold (1.55 log units) above it; measured number outside the range, below it.
By their numbers in this assay, from the lowest: compound 3; then compounds 2 and 1 (each within the scatter of the next).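

In this assay, for the compounds shown here, the position ortho to a methoxy group on the benzyl ring proves far more sensitive than the earlier pair suggested: exchanging methoxy for bromo gives a large step (a 40-fold lower number from compound 2 to compound 3 (1.60 log units; beyond the scatter)), whereas the only earlier change at this aryl group stayed within the scatter (a 1.6-fold lower number from compound 1 to compound 2 (0.20 log units; within the scatter)). The 3-bromo-4-methoxyphenyl group also stands well clear of the 4-methylphenyl group (a 64-fold lower number from compound 1 to compound 3 (1.80 log units; beyond the scatter)), so compound 3 is the only one of the three separated from the others, and a single-atom substituent at this carbon is enough to produce that separation. No measurement shown here bears on why this exchange has so large an effect.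

The series shown holds a single bromo compound, so it remains open whether the step belongs to bromo itself or would also appear with chloro, fluoro, trifluoromethyl or nitrile at the same carbon. Going by these compounds, it is equally open whether the neighbouring methoxy group is needed for the step, which a 3-bromo-4-hydroxybenzyl or plain 3-bromobenzyl analogue would test.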